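Bromo to Iodo on a Shared Core: A Repeated Swap

A few compounds are considered here, and "the series" means these few. Any claim that something is new, unique, unknown or untested is made for them only; others in the source may bear on it.

Three compounds have so far been measured in an ADME assay on the whole organism with Oryza sativa as the target, tested at 0.1 uM; on this read-out lower numbers stand for a stronger effect and higher numbers for a weaker effect at the one concentration tested:
compound 1 `C[C@@H](NC(=O)Nc1ccccc1Br)c1ccccc1` gives 99%
compound 2 `C[C@@H](NC(=O)Nc1cccc(Br)c1)c1ccccc1` gives 100%
compound 3 `C[C@@H](NC(=O)Nc1ccccc1I)c1ccccc1` gives 100%

All three share one core and differ only in the halogen and where it sits. Compound 1 and compound 3 differ in a single place: iodo in place of bromo on an aromatic carbon. That swap produced a number 1 percentage points higher from compound 1 to compound 3 (within the scatter). Compound 2 has the same atoms as compound 1, joined differently; the difference between the two cores is not broken down here.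

Compound 4 `C[C@@H](NC(=O)Nc1cccc(I)c1)c1ccccc1` has not yet been measured. It differs from compound 2 in one place: iodo in place of bromo on an aromatic carbon. Going by the values given here, this is the same kind of change as the one from compound 1 to compound 3, but not the same: in the measured pair the halogen sits ortho to a large group, whereas in compound 4 it sits meta to a large group. Because the earlier swap gave a number 1 percentage points higher from compound 1 to compound 3 (within the scatter) and the three measured values already sit close to the top of the scale, compound 4 is expected to show no change at the digits printed from compound 2 to compound 4 (within the scatter) and to come in near 100%, estimated between 94% and 100%.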

Compound 4, a percentage reported as activity, at one concentration (the size of the read-out at that concentration, not a potency): 81%
Compound 4: middle estimate off by 19 percentage points, on the high side, and the stated range ends above it.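

In this assay, iodo in place of bromo gave a number 19 percentage points lower from compound 2 to compound 4 (beyond the scatter), so this swap did not behave on the core of compound 2 as it had on the core of compound 1. Set side by side, the two results differ by more than ordinary scatter would explain: the same change on two cores in this assay, a number 1 percentage points higher (within the scatter) from compound 1 to compound 3 and a number 19 percentage points lower (beyond the scatter) from compound 2 to compound 4, 20 percentage points apart, beyond the scatter of two such steps This shows that, among these compounds, the outcome of the swap depends on the core that carries it, so a step read on one core cannot simply be transferred to the other; it does not show why the two cores differ, and two pairs give no rule for any further core.

As far as these compounds go, it remains open whether a chloro, methyl or nitrile group on the same aromatic carbon, meta to a large group, would give a number close to that of compound 2 or that of compound 4. From the compounds shown here alone, the read-out also comes from one concentration, so whether the effect of compound 4 would be stronger or weaker than that of compound 2 at any other concentration remains open as well.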